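The source may report more compounds than this note shows. Statements on the series, on what has been measured and on what is new or still open speak of the compounds shown alone.

Measured compounds:

- compound 1 `NC(=S)n1ccc2c(OCCCCCOc3ccc(Cl)cc3)cccc21`: 24700 nM
- compound 2 `O=C(NC(=S)N1CCc2c(OCCCCCOc3ccc(Cl)cc3)cccc21)c1ccc(Cl)cc1`: 21700 nM
- compound 3 `O=C(NC(=S)N1CCc2c(OCCCCCOc3ccc(Cl)cc3)cccc21)c1ccc(Br)cc1`: 29100 nM

All three numbers come from an ADME assay on Huh-7 cells (Homo sapiens) for cytotoxicity; on this read-out lower numbers stand for higher toxicity in this test and higher numbers for lower toxicity in this test. Among the compounds with values here, the three values sit close together: compound 3 gives 29100 nM, and the only single-point step among the measured pairs, a 1.3-fold higher number from compound 2 to compound 3 (0.13 log units; within the scatter), stays within the scatter, so no measured compound can be set apart from the others on this read-out.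

Compound 4 `CN(C)c1ccc(C(=O)NC(=S)N2CCc3c(OCCCCCOc4ccc(Cl)cc4)cccc32)cc1` is the next compound. Relative to compound 3 it carries dimethylamino in place of bromo on an aromatic carbon. Within the data shown here, the one measured step, a 1.3-fold higher number from compound 2 to compound 3 (0.13 log units; within the scatter), exchanged one halogen for another at the same aromatic carbon and moved nothing beyond the scatter; no measured pair exchanges a halogen for dimethylamino, so that part of the change is untested. With three compounds of very different headgroups all falling in the same narrow band, the expectation for compound 4 is a number of the same order, with the step from compound 3 estimated as a 1.2-fold lower number from compound 3 to compound 4 (0.07 log units; within the scatter). The estimate for compound 4 in this assay is 25000 nM, expected to fall between 11000 nM and 55000 nM.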

Compound 4, half-maximal cytotoxic concentration: > 50000 nM
Compound 4: only a limit was reported; the forecaster's own chance of this, stated with the estimate: 25%; at least 2.0-fold (0.30 log units) between middle value and limit.
By their numbers in this assay, from the lowest: compounds 2, 1 and 3 (each within the scatter of the next). At a limit, above all of these: compound 4.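

Compound 4 is reported only as a limit in this assay, not as a number: the limit of > 50000 nM in this assay, at which 1 of the 4 values shown sits. Within the data shown here, putting dimethylamino in place of the halogen on this aromatic carbon gives an at least 2.3-fold higher number from compound 2 to compound 4 (0.36 log units; beyond the scatter), the first step to clear the scatter, so this position can move the read-out towards lower toxicity in this test, which the bromo-for-chloro exchange did not do. Measured against the bromo compound the case is weaker, with an at least 1.7-fold higher number from compound 3 to compound 4 (0.23 log units; that floor lies within the scatter), so that pair cannot yet be firmly separated.

Going by these compounds, how far the true number for compound 4 lies past its limit remains open, so the full size of the change is unknown. Also open, on these data alone, is whether a primary amine, a methoxy group or a carboxylic acid at this position would read like dimethylamino or like the halogens.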